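The source may report more compounds than this note shows. Statements on the series, on what has been measured and on what is new or still open speak of the compounds shown alone.

Measured compounds: compound 1 `CCCCOCNc1n[n+]([O-])c2ccccc2[n+]1[O-]` with 14700 nM; compound 2 `CCCOCNc1n[n+]([O-])c2ccccc2[n+]1[O-]` with 14200 nM.

In a functional assay on PC-3 cells (Homo sapiens) for cytotoxicity, read by MTT assay, with a stated time of 72 h (a higher number here means a weaker inhibitor, a lower number a stronger inhibitor), compound 1 holds the highest of the two numbers, and compound 2 sits nearest, the two lying within the scatter. Compound 3 `CC(C)CCOCNc1n[n+]([O-])c2ccccc2[n+]1[O-]` differs from compound 1 by methyl in place of hydrogen on a saturated chain carbon bound to two saturated chain carbons, so the butyl chain becomes isopentyl. Going by the values given here, the only measured step touching the chain is a 1.0-fold lower number from compound 1 to compound 2 (0.02 log units; within the scatter), a change of chain length that left this assay unmoved. Adding a methyl on the chain is therefore expected to give no step beyond the scatter, with no change at the digits printed from compound 1 to compound 3 (within the scatter) as the estimated step. Compound 3 is expected to show 14700 nM, within 7000 nM to 30000 nM.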

Compound 3, half-maximal inhibitory concentration: 11100 nM
The estimate for compound 3 lay 1.3-fold (0.12 log units) above the measured number, within the range that was stated.
By their numbers in this assay, from the lowest: compounds 3, 2 and 1 (each within the scatter of the next).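

Branching the chain, as in the change from butyl to isopentyl, also stays within the scatter in this assay: the result is a 1.3-fold lower number from compound 1 to compound 3 (0.12 log units; within the scatter), and a 1.3-fold lower number from compound 2 to compound 3 (0.11 log units; within the scatter). Across these three compounds, neither chain length nor this added methyl moves the number beyond the scatter. No other evidence bears on this result.

From the compounds shown here alone, it remains open whether an amine, a carboxylic acid or a phenyl ring at the end of the chain, or a much longer chain, would move the number beyond the scatter.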